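The source may report more compounds than this note shows. Statements on the series, on what has been measured and on what is new or still open speak of the compounds shown alone.

Compound 1 `N=C(N)NCCC[C@H](NC(=O)CN(c1ncnc2c1ncn2C1CCCCO1)C1CC1)C(=O)OCc1ccccc1` gives 19.6% in a functional assay on the whole organism (Tail, strain ICR) with Mus musculus as the target, in the tail flick test, with a stated time of 150 min, at a dose of 25 umol/kg by the oral route; a lower number here means a weaker effect, a higher number a stronger effect of the compound at the dose given.
Compound 2 `O=C(CN(c1ncnc2c1ncn2C1CCCCO1)C1CC1)N[C@@H](CO)C(=O)OCc1ccccc1` gives 18.3%.
Compound 3 `CC[C@H](C)[C@H](NC(=O)CN(c1ncnc2c1ncn2C1CCCCO1)C1CC1)C(=O)OCc1ccccc1` gives 16.4%.

Compound 3 has the smallest of the three numbers, yet the steps of a number 3.2 percentage points lower from compound 1 to compound 3 (within the scatter) and a number 1.9 percentage points lower from compound 2 to compound 3 (within the scatter) both lie within the scatter, so the three compounds cannot be told apart on these data. Compound 4 `O=C(CN(c1ncnc2c1ncn2C1CCCCO1)C1CC1)NCC(=O)OCc1ccccc1` is not yet measured; it differs from compound 3 only in hydrogen in place of sec-butyl on a saturated chain carbon bound to an amide-type nitrogen and a carbonyl carbon. Within the data shown here, the steps that bear on this change are those that swap the side chain at the same place: a number 1.3 percentage points lower from compound 1 to compound 2 (within the scatter), a number 3.2 percentage points lower from compound 1 to compound 3 (within the scatter) and a number 1.9 percentage points lower from compound 2 to compound 3 (within the scatter), each within the scatter. Removing the side chain altogether is therefore expected to give no step beyond the scatter, a number 0.6 percentage points higher from compound 3 to compound 4 (within the scatter). Compound 4 is estimated at 17%, with a range from 8% to 26%.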

Compound 4, a percentage reported as activity, at one dose (the size of the read-out at that dose, not a potency): 7.26%
For compound 4 the middle estimate is 9.7 percentage points above the measured one; the measured number lies below the stated range.
By their numbers in this assay, from the lowest: compounds 4, 3, 2 and 1 (each within the scatter of the next, the first and the last beyond it).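

With hydrogen in place of any side chain on the saturated chain carbon bound to an amide-type nitrogen and a carbonyl carbon, this position gives its first steps beyond the scatter in this assay (a number 11 percentage points lower from compound 2 to compound 4 (beyond the scatter); a number 12.3 percentage points lower from compound 1 to compound 4 (beyond the scatter)). The step from sec-butyl stays inside it (a number 9.1 percentage points lower from compound 3 to compound 4 (within the scatter)), so hydrogen is set apart from hydroxymethyl and from the side chain of compound 1, but not from sec-butyl. No measurement shown gives a reason for these steps. On these data alone, whether a methyl group, an amine or a carboxylic acid at this place would give a number nearer compound 4 or compound 1 stays open.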